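Inverting one ring stereocentre in a phospho-amino-acid ester

The source may report more compounds than this note shows. Statements on the series, on what has been measured and on what is new or still open speak of the compounds shown alone.

Measured compounds:
Compound 1, `Cc1ccc(Oc2cccc(COc3ccccc3CCC(=O)O[C@@H]3CCCO[C@@H]3COP(=O)(O)OC[C@H](N)C(=O)O)c2)cc1`: 16%
Compound 2, `N[C@@H](COP(=O)(O)OC[C@H]1OCC=C[C@H]1OC(=O)CCc1ccccc1OCc1cccc(Oc2ccccc2)c1)C(=O)O`: 16.5%

Both compounds were tested in an assay on HEK293-A cells for agonist activity at probable G-protein coupled receptor 34 (Mus musculus), with a stated time of 1.5 h; a lower number here means a smaller maximal response, a higher number a larger maximal response. Compound 1 gives 16% and compound 2 gives 16.5%, numbers that lie within the scatter of each other, so neither compound stands apart from the other; both reach only a small fraction of the reference response. Within the data shown here, no pair of measured compounds differs in a single place, so no measured step is available to calibrate the next change.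

Compound 3, `N[C@@H](COP(=O)(O)OC[C@H]1OCC=C[C@@H]1OC(=O)CCc1ccccc1OCc1cccc(Oc2ccccc2)c1)C(=O)O`, is not yet measured. It differs from compound 2 as follows: the two compounds have the same atoms and bonds; at least one stereo element is drawn with a configuration in one of them and without one in the other: 1 of 4 stereo elements differ; a stereocentre at a saturated ring carbon is drawn R in compound 2 and S in compound 3. Among the measured compounds shown here, with no comparable measured step to draw on, and with both measured numbers low and close together, the change from compound 2 to compound 3 is expected to produce no step beyond the scatter in this assay, if anything a slight drop. The step of a number 2.5 percentage points lower from compound 2 to compound 3 (within the scatter) is the estimated outcome. Compound 3 is expected to give about 14%, within a range of 5% to 28%.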

Compound 3, largest response reached (Emax), in percent of the reference or control that the assay uses: "not active" (no number reported)
Nothing numeric was reported for compound 3, so the estimate cannot be set against anything.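

In this assay, among these compounds, compound 3 was reported as "not active", without a number, so no step from compound 2 to compound 3 can be read. What the ring stereocentre does to the maximal response stays open, and one caution attaches to this pair: the fact that one of compounds 2 and 3 is drawn with a defined configuration and the other without, at the place where they differ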